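Trimming a hydroxymethyl from compound 2

A few compounds are considered here, and "the series" means these few. Any claim that something is new, unique, unknown or untested is made for them only; others in the source may bear on it.

Measured in a functional assay on Caco-2 cells (Homo sapiens) for antiproliferative activity, read by MTT assay, with a stated time of 48 h; on this read-out higher numbers stand for weaker inhibition and lower numbers for stronger inhibition:
Compound 1 `CCOC(=O)C(CC(=O)OC)NC(=O)c1ccc(C(CC)(CC)c2ccc(OCCC(O)(CC)CC)c(C)c2)n1CC`: 3020 nM
Compound 2 `CCn1c(C(=O)NC(CO)CCO)ccc1C(CC)(CC)c1ccc(OCCC(O)(CC)CC)c(C)c1`: 40200 nM

Of these two, compound 2 has the higher number and is the weaker inhibitor. Compound 3 `CCn1c(C(=O)NC(C)CO)ccc1C(CC)(CC)c1ccc(OCCC(O)(CC)CC)c(C)c1` changes one group: hydrogen in place of hydroxymethyl on a saturated chain carbon, two bonds along the chain from an amide-type nitrogen that is, hydrogen in place of hydroxymethyl on a saturated chain carbon, two bonds along the chain from an amide-type nitrogen. Among the compounds with values here, only one measured step bears on this: a 13-fold higher number from compound 1 to compound 2 (1.12 log units; beyond the scatter) a large step that also changed a group on an amide-type nitrogen. Less is exchanged here, so a smaller step toward stronger inhibition is expected in this assay and the estimate is a 2.5-fold lower number from compound 2 to compound 3 (0.40 log units; beyond the scatter) with real doubt about its direction. Compound 3 is expected at 16000 nM within an estimated range of 5000 nM to 45000 nM for now.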

Compound 3, half-maximal inhibitory concentration: > 50000 nM
Compound 3: a limit, no number; the forecaster's own chance of this, stated with the estimate: 10%; middle value at least 3.1-fold (0.49 log units) away from the limit.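

In this assay compound 3 gives > 50000 nM as a limit of the assay and not a number. Taking away the hydroxymethyl brings no recovery of inhibition: the data show an at least 1.2-fold higher number from compound 2 to compound 3 (0.09 log units; that floor lies within the scatter) as a floor only, and the larger group on the amide-type nitrogen keeps its lead with an at least 16-fold higher number from compound 1 to compound 3 (1.21 log units; beyond the scatter) as the step. The true size of this change stays hidden at the top of the assay's range: the limit of > 50000 nM in this assay, at which 1 of the 3 values shown sits.

On these data alone, whether an amine or a carboxylic acid in place of the hydroxymethyl would restore inhibition stays open. So does which part of the larger group in compound 1 carries its lead.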